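The source may report more compounds than this note shows. Statements on the series, on what has been measured and on what is new or still open speak of the compounds shown alone.

In a functional assay on HT-29 cells (Homo sapiens) for cytotoxicity, read by MTT assay, with a stated time of 24 h, tested at 32 ug/mL (on this read-out lower numbers stand for a weaker effect and higher numbers for a stronger effect at the one concentration tested), compound 1 `Cn1c(-c2ccc(NC(=O)CSc3nc4cc(Cl)ccc4o3)cc2)nc(-c2ccccc2)c1-c1ccccc1` gives 61.9%, compound 2 `Cn1ccnc1SCC(=O)Nc1ccc(-c2nc(-c3ccccc3)c(-c3ccccc3)n2C)cc1` gives 41.1% and compound 3 `CCN1CCN(CC(=O)Nc2ccc(-c3nc(-c4ccccc4)c(-c4ccccc4)n3C)cc2)CC1` gives 38.8%. Compound 3 stands lowest of the three: compound 2 lies within the scatter of it, while compound 1 lies beyond it, as a number 23.1 percentage points lower from compound 1 to compound 3 (beyond the scatter) shows. Compound 4 `Cc1ccc(CN2CCN(CC(=O)Nc3ccc(-c4nc(-c5ccccc5)c(-c5ccccc5)n4C)cc3)CC2)cc1` differs from compound 3 by 4-methylphenyl in place of methyl on a saturated chain carbon bound to an amine nitrogen in a ring. Among the measured compounds shown here, no measured step changes a group on this ring carbon's neighbourhood; a number 20.8 percentage points lower from compound 1 to compound 2 (beyond the scatter) and a number 2.3 percentage points lower from compound 2 to compound 3 (within the scatter) exchange the whole group on the chain carbon bound to the carbonyl carbon, and the second of these is small. The expectation is therefore a step of a number 3.2 percentage points higher from compound 3 to compound 4 (within the scatter), not beyond the scatter. Compound 4 is thus estimated at 42%, with a range from 25% to 60%.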

Compound 4, a percentage reported as activity, at one concentration (the size of the read-out at that concentration, not a potency): 42.3%
The estimate for compound 4 lay 0.3 percentage points below the measured number; the range from low to high includes it.
By their numbers in this assay, from the lowest: compounds 3, 2 and 4 (each within the scatter of the next); then compound 1.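

Earlier steps exchanged the whole group on the chain carbon bound to a carbonyl carbon, whereas this one changes only the outer end of that group, and in this assay the result (a number 3.5 percentage points higher from compound 3 to compound 4 (within the scatter)) stays within the scatter. At this place, on a saturated chain carbon bound to an amine nitrogen in a ring, 4-methylphenyl thus adds a six-membered aromatic ring in place of methyl without a change in the read-out beyond the scatter. No measurement shown here explains this. As far as these compounds go, whether a longer alkyl chain, a hydroxyl group or a carboxylic acid at this place would leave the read-out equally unmoved remains open.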